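Moving a Fluorine: An Expected Flat Step

The source may hold more compounds than are shown below. What is called first, only, known or untested is meant among the compounds shown, and "the series" means these compounds.

In a functional assay on MCF7 cells (Homo sapiens) for antiproliferative activity, read by MTT assay, with a stated time of 48 h (a lower number here means a stronger inhibitor, a higher number a weaker inhibitor), compound 1 `Cc1ccc(/C=C/C(=N/NC(=N)N)c2ccccc2)cc1` gives 16000 nM. Compound 2 `N=C(N)N/N=C(/C=C/c1cccc(F)c1)c1ccccc1` gives 16000 nM, which puts it level with compound 1 at the digits shown. Compound 3 `N=C(N)N/N=C(/C=C/c1ccccc1F)c1ccccc1` has not yet been measured and differs from compound 2 at a single place: 2-fluorophenyl in place of 3-fluorophenyl on a double-bonded chain carbon bound to a double-bonded chain carbon. The two share the same atoms, and the change is 2-fluorophenyl in place of 3-fluorophenyl on a double-bonded chain carbon bound to a double-bonded chain carbon.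

Among the compounds with values here, only one measured step bears on this change, no change at the digits printed from compound 1 to compound 2 (within the scatter). Within the data shown here, it concerns the same place in the molecule, but it is a single comparison, and no measured compound carries the 2-fluorophenyl group. The evidence is therefore thin. Even so, exchanging the group at this place left compound 2 at 16000 nM, so no shift beyond the scatter is expected in this assay, in either direction. The expected size of the step is no change at the digits printed from compound 2 to compound 3 (within the scatter). For compound 3 the estimate is 16000 nM, with an expected range of 7000 nM to 35000 nM.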

Compound 3, half-maximal inhibitory concentration: 3900 nM
The estimate for compound 3 lay 4.1-fold (0.61 log units) above the measured number; the whole stated range lies above it.
By their numbers in this assay, from the lowest: compound 3; then compounds 1 and 2 (each within the scatter of the next).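

The place on a double-bonded chain carbon bound to a double-bonded chain carbon proved more responsive than the earlier pair suggested: in this assay, 2-fluorophenyl in place of 3-fluorophenyl gave a clear shift (a 4.1-fold lower number from compound 2 to compound 3 (0.61 log units; beyond the scatter)), although the exchange between the first two compounds had shown no movement beyond the scatter. The two groups have the same atoms and the same counts, so this step separates two arrangements of one fluorinated ring and shows that the assay can tell them apart, while 2-fluorophenyl in place of 4-methylphenyl gave a shift of the same size (a 4.1-fold lower number from compound 1 to compound 3 (0.61 log units; beyond the scatter)). Nothing measured alongside these numbers accounts for the shift, so its origin remains unexplained.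

The compounds shown leave open whether the lower number in this assay is tied to fluorine itself or would also appear with 2-chlorophenyl or 2-methylphenyl at this place. They also leave open how far the trend extends, for instance to 2,6-difluorophenyl, or to a phenyl ring carrying an amine or a carboxylic acid.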